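Amide size in the weak benzylamine series

A few compounds are considered here, and "the series" means these few. Any claim that something is new, unique, unknown or untested is made for them only; others in the source may bear on it.

Three compounds have numbers in an assay on brain with Translocator protein (Rattus norvegicus) as the target; on this read-out lower numbers stand for stronger inhibition and higher numbers for weaker inhibition. Compound 1 `CCN(Cc1ccccc1)Cc1ccccc1C(=O)N(CC)CC` gives 8210 nM, the highest of the three. Compound 2 `CCN(Cc1ccccc1)Cc1nc2ccccc2c(-c2ccccc2)c1C(=O)N(CC)CC` gives 373 nM and compound 3 `CCOC(=O)c1c(CN2CCc3ccccc3C2)nc2ccccc2c1-c1ccccc1` gives 1190 nM; both gaps to compound 1 lie beyond the scatter, so compound 1 is the weakest binder shown. Compound 4 `CCN(Cc1ccccc1)Cc1ccccc1C(=O)N(C)C` differs from compound 1 in one place: dimethylamino in place of diethylamino on a carbonyl carbon. For the measured compounds named here, no measured pair shows this change, so its size is not known from the series. A step of a 1.9-fold higher number from compound 1 to compound 4 (0.29 log units; within the scatter) is expected, somewhat beyond the scatter and toward weaker binding, since the series offers no case of a smaller amide improving the number. Compound 4 is therefore estimated at 16000 nM, with a range from 5500 nM to 50000 nM.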

Compound 4, half-maximal inhibitory concentration: > 10000 nM
Compound 4 was reported as a limit; the forecaster's own chance of this, stated with the estimate: 25%; the middle value is on the limit's open side.
By their numbers in this assay, from the lowest: compound 2; then compound 3; then compound 1. At a limit, above all of these: compound 4.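

In this assay compound 4 is reported only as a limit, > 10000 nM, so it has no exact number. Dimethylamino in place of diethylamino on a carbonyl carbon gives an at least 1.2-fold higher number from compound 1 to compound 4 (0.08 log units; that floor lies within the scatter), the first reading at this position. The smaller amide shows no sign of a gain here, yet the floor of the step does not establish a loss.

As far as these compounds go, how far the true value of compound 4 lies past its limit stays open. So does whether dipropylamino on the same carbonyl carbon improves on diethylamino, and whether dimethylamino behaves alike on the core of compound 2.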